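This account rests on a few compounds, and the source may have more. Where it says the series, first, only, none or still open, it means among the compounds named here.

Compound 1 `C=CC(=O)Nc1cccc(Nc2nc(N/N=C(\C)c3ccc(F)cc3F)ncc2Cl)c1` carries a 2,4-difluorophenyl group and a vinyl group on its carbonyl carbon. In an ADME assay on HT-29 cells (Homo sapiens) for inhibition, read by MTT assay, with a stated time of 72 h (on this read-out higher numbers stand for weaker inhibition and lower numbers for stronger inhibition), compound 1 gives 4360 nM. Compound 2 `C=CC(=O)Nc1cccc(Nc2nc(N/N=C(\C)c3ccc(C)cc3)ncc2Cl)c1` differs from compound 1 by one change, (4-methylphenyl in place of 2,4-difluorophenyl on a carbon with a double bond to nitrogen), and in this assay compound 2 gives 3210 nM; this change made the step of a 1.4-fold lower number from compound 1 to compound 2 (0.13 log units; within the scatter). Compound 3 `C/C(=N\Nc1ncc(Cl)c(Nc2cccc(NC(=O)/C=C/CN(C)C)c2)n1)c1ccc(F)cc1F` differs from compound 1 by another change, (3-(dimethylamino)prop-1-en-1-yl in place of vinyl on a carbonyl carbon), and in this assay compound 3 gives 3460 nM; that change made the step of a 1.3-fold lower number from compound 1 to compound 3 (0.10 log units; within the scatter).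

Compound 4 `C/C(=N\Nc1ncc(Cl)c(Nc2cccc(NC(=O)/C=C/CN(C)C)c2)n1)c1ccc(C)cc1` is not yet measured. It differs from compound 3 by 4-methylphenyl in place of 2,4-difluorophenyl on a carbon with a double bond to nitrogen, which is the same change, at the same place, that turned compound 1 into compound 2. The cores of the two pairs differ as described by 3-(dimethylamino)prop-1-en-1-yl in place of vinyl on a carbonyl carbon.

Because the step of a 1.4-fold lower number from compound 1 to compound 2 (0.13 log units; within the scatter) was small, the step expected from compound 3 to compound 4 is estimated as a 1.4-fold lower number from compound 3 to compound 4 (0.13 log units; within the scatter), about the same size. In this assay compound 4 is therefore expected to give roughly 2550 nM, with the estimate spanning from 1300 nM to 5000 nM.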

Compound 4, half-maximal inhibitory concentration: 11800 nM
Beside the measured number, compound 4's estimate is 4.6-fold (0.67 log units) below it; measured number above the stated range.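

In this assay, replacing 2,4-difluorophenyl with 4-methylphenyl did not carry over from one core to the other, since on the core with the 3-(dimethylamino)prop-1-en-1-yl group it gave a 3.4-fold higher number from compound 3 to compound 4 (0.53 log units; beyond the scatter), and the two steps clearly differ: the same change on two cores in this assay, a 1.4-fold lower number (0.13 log units; within the scatter) from compound 1 to compound 2 and a 3.4-fold higher number (0.53 log units; beyond the scatter) from compound 3 to compound 4, 4.6-fold (0.67 log units) apart, beyond the scatter of two such steps. Read the other way, putting 3-(dimethylamino)prop-1-en-1-yl in place of vinyl gave a 3.7-fold higher number from compound 2 to compound 4 (0.57 log units; beyond the scatter), so the outcome of this change also depends on the group at the other end of the molecule: the same change on two cores in this assay, a 1.3-fold lower number (0.10 log units; within the scatter) from compound 1 to compound 3 and a 3.7-fold higher number (0.57 log units; beyond the scatter) from compound 2 to compound 4, 4.6-fold (0.67 log units) apart, beyond the scatter of two such steps. Across these four compounds the two changes therefore do not act independently, but the set cannot say why, nor whether other changes in the series would carry over any better.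

As far as these compounds go, it remains open whether the same dependence would appear with a plain phenyl or a 4-chlorophenyl group on that carbon, or with a morpholine or a longer chain in place of the dimethylamino end. From the compounds shown here alone, it is also open whether the pattern would hold in other cell lines.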